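Fluoro for nitro: working notes on the series

The source may report more compounds than this note shows. Statements on the series, on what has been measured and on what is new or still open speak of the compounds shown alone.

Values in a functional assay on MCF7 cells (Homo sapiens) for cytotoxicity, read by MTT assay, with a stated time of 48 h (on this read-out higher numbers stand for weaker inhibition and lower numbers for stronger inhibition), so far:
- compound 1 `C/C(=N/NC(=S)Nc1ccccc1)c1ccccn1` gives 0.18 nM here
- compound 2 `C/C(=N/NC(=S)Nc1cccc([N+](=O)[O-])c1)c1ccccn1` gives 38 nM here

Compound 2 has the higher number of the two (38 nM). Compound 3 `C/C(=N/NC(=S)Nc1cccc(F)c1)c1ccccn1` carries fluoro in place of nitro on an aromatic carbon. Among the measured compounds shown here, only one measured step bears on this, a large one, where nitro replaced hydrogen (a 210-fold higher number from compound 1 to compound 2 (2.32 log units; beyond the scatter)). No fluoro value exists yet, so a sizeable fall back toward compound 1 is expected in this assay, short of the full distance. The estimated change is a 13-fold lower number from compound 2 to compound 3 (1.10 log units; beyond the scatter) at its middle. For compound 3 the estimate is 3 nM as the expected value, with an expected range of 0.4 nM to 25 nM overall.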

Compound 3, half-maximal inhibitory concentration: 9 nM
Estimate against measurement, compound 3: 3.0-fold (0.48 log units) below, within the range that was stated.
By their numbers in this assay, from the lowest: compound 1; then compound 3; then compound 2.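

In this assay, fluoro in place of nitro recovers only part of the loss at this position (a 4.2-fold lower number from compound 2 to compound 3 (0.63 log units; beyond the scatter)), and fluoro still stands well short of hydrogen (a 50-fold higher number from compound 1 to compound 3 (1.70 log units; beyond the scatter)). On this aromatic carbon, meta to a large group, both groups shown therefore give higher numbers than hydrogen, even though fluoro is a single heavy atom. Nothing available explains the gap between fluoro and nitro.

As far as these compounds go, whether an amine or a carboxylic acid here would fall nearer compound 1 or compound 2 remains open. So does the outcome of fluoro on the other carbons of the same aromatic ring.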